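An Ethoxy Substituent Added to a Shared Core

The compounds below may be only part of what the source reports. "The series", "measured", "known", "first", "only" and "open" are said of these compounds alone.

compound 1: `Cc1ccc2nc(NC(=S)Nc3ccccc3)sc2c1` — > 50000 nM
compound 2: `S=C(Nc1ccccc1)Nc1nc2ccccc2s1` — > 50000 nM

In a functional assay on B16-F10 cells (Mus musculus) for cytotoxicity, read by MTT assay, with a stated time of 48 h (on this read-out lower numbers stand for stronger inhibition and higher numbers for weaker inhibition), compound 1 gives only an assay limit, > 50000 nM. Compound 2 likewise gives only a limit, > 50000 nM. The step that the two limits leave unreadable from compound 1 to compound 2 therefore has no readable size; the limit of > 50000 nM in this assay, at which 2 of the 2 values shown sit, marks where both values sit. Compound 3, `CCOc1ccc2nc(NC(=S)Nc3ccccc3)sc2c1`, differs from compound 2 by ethoxy in place of hydrogen on an aromatic carbon. Among the measured compounds shown here, with no measured step of readable size to draw on, no direction beyond the scatter can be expected in this assay, and compound 3 is expected most likely to give only a limit again. Compound 3 is therefore estimated at 50000 nM, with a range from 20000 nM to 100000 nM, an expected step of a number no higher from compound 2 to compound 3 (the limit leaves the size open).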

Compound 3, half-maximal inhibitory concentration: > 50000 nM
Compound 3: a limit, no number (the forecaster's own chance of this, stated with the estimate: 80%); the middle value lies on the limit itself.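

The steps among compound 1, compound 2 and compound 3 cannot be read, as each gives only a limit in this assay: the limit of > 50000 nM in this assay, at which 3 of the 3 values shown sit.

The compounds shown leave open how hydrogen, methyl and ethoxy compare on the shared core.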